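The compounds below may be only part of what the source reports. "The series", "measured", "known", "first", "only" and "open" are said of these compounds alone.

Measured so far:
compound 1 `Cc1cccc(NC(=O)c2cc3ccccc3oc2=O)c1`, 14500 nM in an in vitro assay on BTI-TN-5B1-4 cells for inhibition of Amine oxidase [flavin-containing] A (Homo sapiens), read by fluorescence; on this read-out lower numbers stand for stronger inhibition and higher numbers for weaker inhibition
compound 2 `Cc1ccc(NC(=O)c2cc3ccccc3oc2=O)cc1`, 19500 nM in this assay
compound 3 `CCc1ccc(NC(=O)c2cc3ccccc3oc2=O)cc1`, 15700 nM in this assay

The three numbers in this assay all sit within the scatter of one another; compound 3 is neither the highest nor the lowest of them. Compound 4 `CC(C)c1ccc(NC(=O)c2cc3ccccc3oc2=O)cc1` differs from compound 3 by methyl in place of hydrogen on a saturated chain carbon bound to an aromatic carbon and a saturated chain carbon. Among the measured compounds shown here, the one step of the same kind, a 1.2-fold lower number from compound 2 to compound 3 (0.09 log units; within the scatter), moved nothing beyond the scatter; the shift of the methyl around the ring, a 1.3-fold higher number from compound 1 to compound 2 (0.13 log units; within the scatter), also stayed within it. A further methyl on the same chain carbon is therefore expected to give no step beyond the scatter in this assay, in either direction: the expected step is a 1.0-fold lower number from compound 3 to compound 4 (0.02 log units; within the scatter). Compound 4 is estimated at 15000 nM, with a range from 7000 nM to 33000 nM.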

Compound 4, half-maximal inhibitory concentration: 15100 nM
Compound 4: the middle estimate sits 1.0-fold (0.00 log units) below what was measured; the measured number falls inside the stated range.
By their numbers in this assay, from the lowest: compounds 1, 4, 3 and 2 (each within the scatter of the next).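

In this assay ethyl to isopropyl on this saturated chain carbon gives a small step (a 1.0-fold lower number from compound 3 to compound 4 (0.02 log units; within the scatter)), and the wider change of isopropyl in place of methyl on an aromatic carbon also stays small (a 1.3-fold lower number from compound 2 to compound 4 (0.11 log units; within the scatter)). A branched chain at this place therefore reads like the straight chains, and the second methyl on this chain carbon, like the first, gives no step beyond the scatter. No evidence on the reason accompanies these numbers.

Open, going by these compounds, is whether the read-out of this assay would move beyond the scatter with an amine, a carboxylic acid or a longer chain in place of isopropyl.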